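The compounds below may be only part of what the source reports. "The series", "measured", "known", "first", "only" and "open" are said of these compounds alone.

Compound 1 `c1ccc(-c2cn3ccnc3c(-c3ccc4ncn(C5CCCCC5)c4c3)n2)cc1` carries an unsubstituted phenyl on the shared core, and in a functional assay on SR cells (Homo sapiens) for inhibition, read by sulforhodamine B assay, with a stated time of 48 h, tested at 10 uM (on this read-out lower numbers stand for less inhibition and higher numbers for more inhibition at the one concentration tested (going by the name of the read-out)), compound 1 gives 59.8%. Among the measured compounds shown here, compound 2 `CC(=O)c1ccc(-c2cn3ccnc3c(-c3ccc4ncn(C5CCCCC5)c4c3)n2)cc1` adds an acetyl to that phenyl; in this assay compound 2 gives 23.6%, the lowest of the two numbers so far, reached through the step of a number 36.2 percentage points lower from compound 1 to compound 2 (beyond the scatter). Compound 3 `FC(F)(F)c1cccc(-c2cn3ccnc3c(-c3ccc4ncn(C5CCCCC5)c4c3)n2)c1` differs from compound 2 by 3-(trifluoromethyl)phenyl in place of 4-acetylphenyl on an aromatic carbon. For the measured compounds named here, no measured pair covers this exchange directly. Going by the values given here, the only step that bears on it, a number 36.2 percentage points lower from compound 1 to compound 2 (beyond the scatter), shows that a group on the outer phenyl can move the read-out strongly, but compound 3 trades one substituted phenyl for another, so the direction is open and the expectation leans back toward the value of compound 1 with wide uncertainty. The expected step is a number 18.4 percentage points higher from compound 2 to compound 3 (beyond the scatter). Compound 3 is estimated at 42%, with a range from 12% to 72%.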

Compound 3, a percentage reported as inhibition, at one concentration (the size of the read-out at that concentration, not a potency): 15.6%
Compound 3: the middle estimate sits 26.4 percentage points above what was measured; the measured number falls inside the stated range.
By their numbers in this assay, from the lowest: compounds 3 and 2 (each within the scatter of the next); then compound 1.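

Exchanging 4-acetylphenyl for 3-(trifluoromethyl)phenyl in this assay leaves the two compounds unseparated (a number 8 percentage points lower from compound 2 to compound 3 (within the scatter)), so the low number is not tied to the acetyl or its carbonyl. Set against the unsubstituted phenyl, trifluoromethyl also brings a large drop (a number 44.2 percentage points lower from compound 1 to compound 3 (beyond the scatter)), so both substituted phenyls lie well under compound 1, and none of the three compounds goes against this. No measurement at hand explains why either group has this effect.

Among the compounds shown here, these compounds carry different groups at different places on the phenyl, so no pair separates the effect of the group from that of its place. From the compounds shown here alone, it also remains open whether a fluorine, a methoxy group, an amine or a carboxylic acid on this phenyl would stay near compound 1 or fall with compound 2 and compound 3.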